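Swapping the aryl group on a five-membered ring

A few compounds are considered here, and "the series" means these few. Any claim that something is new, unique, unknown or untested is made for them only; others in the source may bear on it.

Compound 1 `Cc1nc2cc(OC[C@H](O)CN3CCN(Cc4noc(-c5ccc(C(F)(F)F)cc5)n4)CC3)ccc2s1` is tested in a functional assay on mitochondria from heart for inhibition of peroxisomal acyl-coenzyme A oxidase 1 (Rattus norvegicus) (a higher number here means a weaker inhibitor, a lower number a stronger inhibitor), and gives 380 nM. Compound 2 `Cc1nc2cc(OC[C@H](O)CN3CCN(Cc4nnc(-c5ccc(C(C)(C)C)cc5)o4)CC3)ccc2s1`, in this assay, gives 1100 nM, so compound 1 has the lower of the two numbers. Compound 3 `Cc1cccc(-c2nc(CN3CCN(C[C@@H](O)COc4ccc5sc(C)nc5c4)CC3)no2)c1` is not yet measured; it differs from compound 1 by 3-methylphenyl in place of 4-(trifluoromethyl)phenyl on an aromatic carbon. For the measured compounds named here, no measured pair shows a change of just this kind, so the direction is uncertain, and a step from compound 1 to compound 3 of modest size, a 1.7-fold higher number from compound 1 to compound 3 (0.23 log units; within the scatter), is expected, possibly within the scatter. Compound 3 is estimated at 650 nM, in a range from 220 nM to 2000 nM.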

Compound 3, half-maximal inhibitory concentration: 6500 nM
Beside the measured number, compound 3's estimate is 10-fold (1.00 log units) below it; measured number outside the range, above it.
By their numbers in this assay, from the lowest: compound 1; then compound 2; then compound 3.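

Changing the aryl group on this five-membered ring can shift the result sharply in this assay: 3-methylphenyl in place of 4-(trifluoromethyl)phenyl gives a 17-fold higher number from compound 1 to compound 3 (1.23 log units; beyond the scatter). For the compounds shown here, this is the first measured change in a single place, and it shows that this position does not accept these two aryl groups alike. Nothing measured here explains the difference.

The names of the two groups show that both the substituent and its place on the phenyl ring change, and these compounds cannot separate those two changes. From the compounds shown here alone, how a plain phenyl or a chlorophenyl group would behave here also remains open.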